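Hydroxy-methylphenyl variant of compound 1: expected cytotoxicity

The source may hold more compounds than are shown below. What is called first, only, known or untested is meant among the compounds shown, and "the series" means these compounds.

Compound 1 `Cc1ccccc1-c1nnc(SCCn2c([N+](=O)[O-])cnc2C)o1` is the reference for this step. In a functional assay on MCF7 cells (Homo sapiens) for cytotoxicity, read by MTT assay, with a stated time of 48 h (on this read-out higher numbers stand for weaker inhibition and lower numbers for stronger inhibition), compound 1 gives 15800 nM, the second highest of the three numbers recorded so far. Compound 2 `Cc1ccc(-c2nnc(SCCn3c([N+](=O)[O-])cnc3C)o2)cc1` gives 15500 nM and compound 3 `Cc1ncc([N+](=O)[O-])n1CCSc1nnc(-c2ccc(N)cc2)o1` gives 19800 nM; the three sit close together, with a 1.0-fold lower number from compound 1 to compound 2 (0.01 log units; within the scatter), a 1.3-fold higher number from compound 1 to compound 3 (0.10 log units; within the scatter) and a 1.3-fold higher number from compound 2 to compound 3 (0.11 log units; within the scatter), each within the scatter. Within the measured set, changing the substituent on the phenyl attached to the shared core leaves the read-out essentially unchanged.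

Compound 4 `Cc1cccc(-c2nnc(SCCn3c([N+](=O)[O-])cnc3C)o2)c1O` is not yet measured. It differs from compound 1 as follows: 2-hydroxy-3-methylphenyl in place of 2-methylphenyl on an aromatic carbon. Among the compounds with values here, no measured step introduces a hydroxy group, so nothing bears directly on this change; what the measured steps show is that moving a methyl on that ring, or replacing it by an amino group, stays within the scatter. On that basis a step of no more than the scatter is expected from compound 1 to compound 4, a 1.0-fold higher number from compound 1 to compound 4 (0.01 log units; within the scatter), in no particular direction. The estimate for compound 4 in this assay is 16000 nM, with a range from 7000 nM to 36000 nM.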

Compound 4, half-maximal inhibitory concentration: 19900 nM
Compound 4: middle estimate off by 1.2-fold (0.09 log units), on the low side; the range from low to high includes it.
By their numbers in this assay, from the lowest: compounds 2, 1, 3 and 4 (each within the scatter of the next).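

In this assay, within the data shown here, the 2-hydroxy-3-methylphenyl group in place of 2-methylphenyl gives a 1.3-fold higher number from compound 1 to compound 4 (0.10 log units; within the scatter), so this position on the shared core takes a ring with a hydrogen-bond donor and a hydrogen-bond acceptor without the read-out leaving the scatter, which the methyl and amino changes among the earlier compounds could not show. The comparisons with the other two compounds agree, with a 1.0-fold higher number from compound 3 to compound 4 (0.00 log units; within the scatter) and a 1.3-fold higher number from compound 2 to compound 4 (0.11 log units; within the scatter), so the hydroxy-bearing ring is not set apart from the 4-aminophenyl or the 4-methylphenyl ring in this read-out, and all four compounds remain within the scatter of their neighbours in the order of their numbers. No supporting measurement is available to account for this flat response.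

Going by these compounds, whether a carboxylic acid or a dimethylamino group on the phenyl, or a cyclohexyl ring in place of the phenyl, would move the number beyond the scatter remains open. On these data alone, the rest of the shared core is the same in all four compounds, so the weight of the nitro group or of the chain joining the two ring systems in this read-out also stays unknown.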